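The source may hold more compounds than are shown below. What is called first, only, known or untested is meant among the compounds shown, and "the series" means these compounds.

Measured compounds and their values:

Compound 1 `CC(C)n1ncc2c(C(=O)NCc3cn(-c4ccc(F)cc4)nn3)cccc21`: in a functional assay on MGC-803 cells (Homo sapiens) for inhibition, read by MTT assay, with a stated time of 72 h (a higher number here means a weaker inhibitor, a lower number a stronger inhibitor), compound 1 gives > 40000 nM, which is a limit of the assay rather than a number.
Compound 2 `Cc1cccc(-n2cc(CNC(=O)c3cccc4c3cnn4C(C)C)nn2)c1`: in this assay compound 2 gives > 40000 nM, again only a limit.
Compound 3 `CC(C)n1ncc2c(C(=O)NCc3cn(-c4ccccc4F)nn3)cccc21`: in this assay compound 3 gives > 40000 nM, also a limit.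

Within the data shown here, compound 3 therefore stands where every compound so far stands: at the limit of > 40000 nM in this assay, at which 3 of the 3 values shown sit. Compound 4 `CC(C)n1ncc2c(C(=O)NCc3cn(-c4ccc(C(F)(F)F)cc4)nn3)cccc21` differs from compound 3 in one place: 4-(trifluoromethyl)phenyl in place of 2-fluorophenyl on an aromatic nitrogen. The measured steps that bear on a change of the group on that aromatic nitrogen are a step that the two limits leave unreadable from compound 1 to compound 2, a step that the two limits leave unreadable from compound 1 to compound 3 and a step that the two limits leave unreadable from compound 2 to compound 3. None of them can be read, so no direction and no size can be taken from them, and nothing in the shown numbers tells whether a 4-(trifluoromethyl)phenyl group would move the result away from the limit. The most likely outcome is that compound 4 also comes back as a limit. Compound 4 is therefore expected to give 40000 nM, with a range from 10000 nM to 100000 nM. This estimate means a step of about a number no higher from compound 3 to compound 4 (the limit leaves the size open), which is expected to be none beyond the scatter.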

Compound 4, half-maximal inhibitory concentration: > 40000 nM
Compound 4 gave a limit, no number; the forecaster's own chance of this, stated with the estimate: 80%; the middle value lies on the limit itself.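

In this assay, among these compounds, compound 4 gives > 40000 nM, a limit and not a number, so no step from compound 1, compound 2 or compound 3 to compound 4 can be read: the limit of > 40000 nM in this assay, at which 4 of the 4 values shown sit. The compounds shown leave open whether any group on that aromatic nitrogen can bring the result away from the limit.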